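The source may report more compounds than this note shows. Statements on the series, on what has been measured and on what is new or still open speak of the compounds shown alone.

Compound 1 `CN(C)C12CC(O)C(C(c3ccc(Cl)cc3)C1)C(c1ccc(Cl)cc1)C2`: 8770 nM
Compound 2 `OC1CC2(N3CCCC3)CC(c3ccc(Cl)cc3)C1C(c1ccc(Cl)cc1)C2`: 3590 nM

In an ADME assay on L6 cells (Rattus norvegicus) for cytotoxicity (on this read-out lower numbers stand for stronger inhibition and higher numbers for weaker inhibition), compound 2 has the lower of the two measured numbers, at 3590 nM. Compound 3 `OC1CC2(N3CCCCC3)CC(c3ccc(Cl)cc3)C1C(c1ccc(Cl)cc1)C2`, not yet measured, has piperidin-1-yl in place of pyrrolidin-1-yl on a saturated ring carbon. Within the data shown here, only one measured step bears on this change, a modest swap at the same ring carbon: a 2.4-fold lower number from compound 1 to compound 2 (0.39 log units; beyond the scatter). One step is a thin guide, so only a small change is expected, probably none beyond the scatter. The expected step is a 1.2-fold lower number from compound 2 to compound 3 (0.08 log units; within the scatter). For compound 3 the estimate is 3000 nM, with an expected range of 1300 nM to 7000 nM.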

Compound 3, half-maximal inhibitory concentration: 11600 nM
Compound 3: middle estimate off by 3.9-fold (0.59 log units), on the low side; the whole stated range lies below it.
By their numbers in this assay, from the lowest: compound 2; then compounds 1 and 3 (each within the scatter of the next).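

In this assay, the size of the amine ring on this saturated ring carbon makes a difference: replacing the five-membered pyrrolidin-1-yl ring with the six-membered piperidin-1-yl ring gives a 3.2-fold higher number from compound 2 to compound 3 (0.51 log units; beyond the scatter) in this series. A ring amine alone therefore does not bring the lower number, since replacing dimethylamino with piperidin-1-yl gives only a 1.3-fold higher number from compound 1 to compound 3 (0.12 log units; within the scatter) on the same core. No available evidence explains the difference between the two rings.

The compounds shown leave open how azetidin-1-yl, with a smaller ring, or morpholin-4-yl, with a ring oxygen, would behave at this position. They also leave open whether the effect of ring size holds on other cores.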